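The source may report more compounds than this note shows. Statements on the series, on what has been measured and on what is new or still open speak of the compounds shown alone.

Compound 1 `Cc1ccc(-n2cc(-c3ccccc3NS(=O)(=O)c3c[nH]c(=O)[nH]c3=O)nn2)cc1`: 2190 nM
Compound 2 `O=c1[nH]cc(S(=O)(=O)Nc2ccccc2-c2cn(-c3ccccc3F)nn2)c(=O)[nH]1`: 15300 nM
Compound 3 `Cc1ccc(-n2cc(-c3ccc(NS(=O)(=O)c4c[nH]c(=O)[nH]c4=O)cc3)nn2)cc1`: 5630 nM

These three compounds were tested in a functional assay on OVCAR-3 cells (Homo sapiens) for antiproliferative activity, read by MTT assay, with a stated time of 24 h; on this read-out higher numbers stand for weaker inhibition and lower numbers for stronger inhibition. Compound 2 differs from compound 1 by 2-fluorophenyl in place of 4-methylphenyl on an aromatic nitrogen, and this change gave a 7.0-fold higher number from compound 1 to compound 2 (0.84 log units; beyond the scatter). Compound 3 has the same atoms as compound 1 joined differently; the difference between the two cores is not broken down here. Compound 4 `O=c1[nH]cc(S(=O)(=O)Nc2ccc(-c3cn(-c4ccccc4F)nn3)cc2)c(=O)[nH]1` has not yet been measured in this assay. It differs from compound 3 by 2-fluorophenyl in place of 4-methylphenyl on an aromatic nitrogen, the same change as that from compound 1 to compound 2, at a place described in identical words. The expectation for compound 4 rests on the step of a 7.0-fold higher number from compound 1 to compound 2 (0.84 log units; beyond the scatter), with some allowance for the different core. Compound 4 is expected to show a step of a 5.3-fold higher number from compound 3 to compound 4 (0.73 log units; beyond the scatter). Compound 4 is estimated at 30000 nM, between 12000 nM and 80000 nM.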

Compound 4, half-maximal inhibitory concentration: 8030 nM
Beside the measured number, compound 4's estimate is 3.7-fold (0.57 log units) above it; the whole stated range lies above it.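

In this assay, within the data shown here, the swap of 4-methylphenyl for 2-fluorophenyl on the aromatic nitrogen gave a 1.4-fold higher number from compound 3 to compound 4 (0.15 log units; within the scatter) and so left no step that stands clear of the scatter on this core. The change therefore did not carry over in size, and the two cores responded differently: the same change on two cores in this assay, a 7.0-fold higher number (0.84 log units; beyond the scatter) from compound 1 to compound 2 and a 1.4-fold higher number (0.15 log units; within the scatter) from compound 3 to compound 4, 4.9-fold (0.69 log units) apart, beyond the scatter of two such steps. This shows that the step measured on one core was a poor guide to the step on the other, but with a single pair on each core it does not show why they differ or how the change would behave on any further core. The compounds shown leave open whether other groups on the aromatic nitrogen, such as a benzyl group or a longer alkyl chain, would also respond differently on the two cores.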